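Phenyl for chloro at the aryl ketone end

The source may hold more compounds than are shown below. What is called first, only, known or untested is meant among the compounds shown, and "the series" means these compounds.

Compound 1 `CC(=O)c1ccc(Nc2ccnc(SCC(=O)c3ccc(Br)cc3)n2)cc1`: 25%
Compound 2 `CC(=O)c1ccc(Nc2ccnc(SCC(=O)c3ccc(Cl)cc3)n2)cc1`: "not determined" (no result reported)

Two measured compounds share one core and differ only in the group on the aryl ketone. In a functional assay on SR cells (Homo sapiens) for inhibition, read by sulforhodamine B assay, with a stated time of 48 h, tested at 10 uM (a lower number here means less inhibition of growth, a higher number more inhibition of growth at the concentration tested), compound 1 gives 25%. Compound 2, the chloro analogue, has no single number in this assay, as its result there is recorded as "not determined" (no result reported); it therefore stands nowhere on the numbers shown and offers no anchor of its own. The unmeasured compound 3 `CC(=O)c1ccc(Nc2ccnc(SCC(=O)c3ccc(-c4ccccc4)cc3)n2)cc1` is reached from compound 2 by the change (phenyl in place of chloro on an aromatic carbon). For the measured compounds named here, with no step between measured compounds to draw on, the size of the shift in this assay from compound 2 to compound 3 cannot be read from the data; a modest move in either direction, or none beyond the scatter, is all that can be said. Taking compound 1 as the nearest measured point, compound 3 is expected to give about 30%, within an estimated range from 5% to 60%.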

Compound 3, percent growth inhibition at one concentration: 41%
Estimate against measurement, compound 3: 11 percentage points below; low and high end bracket the measured number.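

In this assay, phenyl in place of bromo on the aromatic carbon of the aryl ketone brings a number 16 percentage points higher from compound 1 to compound 3 (beyond the scatter) on the shared core. This shows that the position accepts a six-membered aromatic ring of carbon only, with no loss of growth inhibition at the concentration tested, and that the replacement of a single halogen atom by this ring moves the result beyond the scatter. The step from compound 2 to compound 3 cannot be read, since compound 2 has no number, and nothing shown here accounts for the step that can be read.

The compounds shown leave open how a morpholine, an amine or a carboxylic acid would behave at this position. They also leave open whether a second ring joined through a longer chain, or a methoxy group, would fall nearer to compound 1 or to compound 3.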